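The source may report more compounds than this note shows. Statements on the series, on what has been measured and on what is new or still open speak of the compounds shown alone.

Of the compounds shown here, three built on a shared core have been tested in a functional assay on K562 cells (Homo sapiens) for inhibition, read by MTT assay, with a stated time of 72 h; on this read-out lower numbers stand for stronger inhibition and higher numbers for weaker inhibition. Compound 1 `Cc1ccc(-c2cn(-c3ccc(CN4CCN(C)CC4)c(C(F)(F)F)c3)nn2)cc1Nc1nccc(-c2cccnc2)n1` gives 30 nM, compound 2 `Cc1ccc(-c2cn(-c3ccc(CN4CCCCC4)cc3)nn2)cc1Nc1nccc(-c2cccnc2)n1` gives 3290 nM, and compound 3 `Cc1ccc(-n2cc(-c3ccc(CN4CCN(C)CC4)cc3)nn2)cc1Nc1nccc(-c2cccnc2)n1` gives 790 nM, the second highest of the three numbers and beyond the scatter from both of the others. Compound 4 `Cc1ccc(-n2cc(-c3ccc(CN4CCN(C)CC4)c(C(F)(F)F)c3)nn2)cc1Nc1nccc(-c2cccnc2)n1` is compound 3 with a single change: trifluoromethyl in place of hydrogen on an aromatic carbon. Among the compounds with values here, no measured pair shows this change on its own, so its size is uncertain. Compound 1 carries the same trifluoromethyl and gives the lowest number, but it differs from compound 4 in a second place as well, so it is only a loose guide. On that basis compound 4 is expected at 200 nM, within a range from 50 nM to 800 nM. That estimate corresponds to an expected moderate drop, a 4.0-fold lower number from compound 3 to compound 4 (0.60 log units; beyond the scatter).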

Compound 4, half-maximal inhibitory concentration: 40 nM
Estimate against measurement, compound 4: 5.0-fold (0.70 log units) above, and the stated range ends above it.
By their numbers in this assay, from the lowest: compounds 1 and 4 (each within the scatter of the next); then compound 3; then compound 2.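

In this assay, trifluoromethyl in place of hydrogen on this aromatic carbon, ortho to a (4-methylpiperazin-1-yl)methyl group, gives a 20-fold lower number from compound 3 to compound 4 (1.30 log units; beyond the scatter) and so is a large change. The earlier compounds shown here held no pair that isolated this change, and now its size at this position is measured directly. Nothing available here explains the drop. As far as these compounds go, whether a chlorine atom, a methyl or a nitrile on the same carbon would give a similar drop remains open. So does whether trifluoromethyl would give a drop of this size with a piperidine in place of the 4-methylpiperazine.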